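The source may hold more compounds than are shown below. What is called first, only, known or untested is meant among the compounds shown, and "the series" means these compounds.

Working notes on the series. In a functional assay on thoracic aorta (Rattus norvegicus, strain Wistar), with a stated time of 15 min (a lower number here means that less compound is needed, a higher number that more compound is needed for the effect), compound 1 (`CCOc1ccc(F)cc1C(C)NC(=O)NS(=O)(=O)c1ccc(C)cc1`) is reported only as a limit, > 300000 nM. Among the compounds with values here, compound 2 (`CCOc1ccc(F)cc1C(C)NC(=O)N(C)S(=O)(=O)c1ccc(C)cc1`) gives 7800 nM, the only actual number so far, so it has no measured neighbour to be ranked against. Within the data shown here, the one measured step, an at least 38-fold lower number from compound 1 to compound 2 (1.58 log units; beyond the scatter), is large and comes with methyl in place of hydrogen on an amide-type nitrogen. Compound 3 (`CCOc1ccc(Br)cc1C(C)NC(=O)N(C)S(=O)(=O)c1ccc(C)cc1`) keeps that methyl and differs from compound 2 elsewhere: bromo in place of fluoro on an aromatic carbon, para to an ethoxy group. Among the measured compounds shown here, the step measured from compound 1 therefore gives no size for this change, and no measured step covers the aromatic carbon. The expected shift in this assay is none beyond the scatter, with no direction favoured. The estimated step is a 1.2-fold lower number from compound 2 to compound 3 (0.08 log units; within the scatter). For compound 3 the expected value is 6500 nM, with an estimated range of 2200 nM to 20000 nM.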

Compound 3, half-maximal effective concentration: 28600 nM
Compound 3: middle estimate off by 4.4-fold (0.64 log units), on the low side, outside the stated range (above it).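

The aromatic carbon para to an ethoxy group is not indifferent in this assay: bromo in place of fluoro gives a 3.7-fold higher number from compound 2 to compound 3 (0.56 log units; beyond the scatter) and so provides the first measured size for a change at this position. The methyl on the amide-type nitrogen is shared by both compounds, so this step belongs to the exchange of fluoro for bromo alone, and compound 3 still gives a measured number rather than a limit. Nothing at hand accounts for the step.

On these data alone, with only fluoro and bromo at this carbon, the pair gives one step and no trend, and whether chloro or methoxy there would fall between compound 2 and compound 3 stays open. Also open, as far as these compounds go, is whether the step holds with the amide hydrogen of compound 1 in place of the methyl.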